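This account rests on a few compounds, and the source may have more. Where it says the series, first, only, none or still open, it means among the compounds named here.

For the measured compounds named here, in an in vitro functional assay on cells for agonist activity at Bombesin receptor subtype-3 (Homo sapiens), read by luminescence and calcium flux (on this read-out lower numbers stand for an effect already at smaller amounts and higher numbers for an effect only at larger amounts of compound), compound 3 `N#Cc1ccccc1Cc1cnc(CCc2ccc(-c3ccccc3C(=O)O)cc2)[nH]1` gives 5480 nM, the highest number among the three compounds measured so far. Compound 1 `O=C(O)c1ccccc1-c1ccc(CCc2ncc(CCC3CCCCC3)[nH]2)cc1` gives 642 nM, and compound 2 `CC(C)(C)CCc1cnc(CCc2ccc(-c3ccccc3C(=O)O)cc2)[nH]1` gives 39 nM. The step of an 8.5-fold higher number from compound 1 to compound 3 (0.93 log units; beyond the scatter) and the step of a 140-fold higher number from compound 2 to compound 3 (2.15 log units; beyond the scatter) both show that placing a 2-cyanophenyl group at this position goes with clearly higher numbers than a saturated group there. Compound 4 `Cc1ccc(Cc2cnc(CCc3ccc(-c4ccccc4C(=O)O)cc3)[nH]2)cc1` carries the change (4-methylphenyl in place of 2-cyanophenyl on a saturated chain carbon bound to an aromatic carbon). Going by the values given here, no measured step swaps one aromatic group for another at this place, so the expectation rests only on those two steps, which point to a lower number once the 2-cyanophenyl group is gone. Compound 4 is therefore expected to show a lower number, a step of a 3.7-fold lower number from compound 3 to compound 4 (0.56 log units; beyond the scatter), with an estimate of 1500 nM and a range from 300 nM to 8000 nM.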

Compound 4, half-maximal effective concentration: 2660 nM
For compound 4 the middle estimate is 1.8-fold (0.25 log units) below the measured one, and the stated range covers the measured number.
By their numbers in this assay, from the lowest: compound 2; then compound 1; then compound 4; then compound 3.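

In this assay, exchanging one aromatic group for another gives only a modest change, a 2.1-fold lower number from compound 3 to compound 4 (0.31 log units; beyond the scatter), so the high number of compound 3 does not depend on 2-cyanophenyl alone. Compound 4 also stays above both compounds with saturated groups, with a 4.1-fold higher number from compound 1 to compound 4 (0.62 log units; beyond the scatter) and a 68-fold higher number from compound 2 to compound 4 (1.83 log units; beyond the scatter), and among these four compounds none goes against this split. Nothing available explains the split.

Because 2-cyanophenyl and 4-methylphenyl differ in both the substituent and where it sits, this step cannot separate those two changes. On these data alone, how plain phenyl, or a phenyl carrying an amine, would behave here remains open.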